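This account rests on a few compounds, and the source may have more. Where it says the series, first, only, none or still open, it means among the compounds named here.

Measured in a functional assay on A549 cells (Homo sapiens) for antiproliferative activity, read by MTT assay, with a stated time of 48 h; on this read-out lower numbers stand for stronger inhibition and higher numbers for weaker inhibition:
- compound 1 `COc1ccc(C(=O)c2ccc(OC)c3c2C=CC(C)(C)O3)c(NC(=O)CBr)c1`: 2460 nM
- compound 2 `COc1ccc(C(=O)c2ccc3c(c2)C=CC(C)(C)O3)c(NC(=O)CN)c1`: 310 nM
- compound 3 `CNCC(=O)Nc1cc(OC)ccc1C(=O)c1ccc(OC)c2c1OC(C)(C)C=C2`: 620 nM

Compound 1 stands highest of these three in this assay. Its number lies beyond the scatter from both others, nearest to compound 3 and furthest from compound 2. Compound 4 `CCNCC(=O)Nc1cc(OC)ccc1C(=O)c1ccc(OC)c2c1C=CC(C)(C)O2` has not yet been measured. It departs from compound 1 by ethylamino in place of bromo on a saturated chain carbon bound to a carbonyl carbon, with ethylamino in place of bromo on a saturated chain carbon bound to a carbonyl carbon. Among the measured compounds shown here, no measured pair differs in one place only, so the expectation rests on the values alone. Compound 2 at 310 nM and compound 3 at 620 nM carry no bromo, unlike compound 1 at 2460 nM. A lower number is therefore expected, beyond the scatter, and the estimated change is a 3.5-fold lower number from compound 1 to compound 4 (0.55 log units; beyond the scatter). Compound 4 is expected at 700 nM, with an estimated range from 250 nM to 2000 nM.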

Compound 4, half-maximal inhibitory concentration: 2310 nM
Beside the measured number, compound 4's estimate is 3.3-fold (0.52 log units) below it, and the stated range ends below it.
By their numbers in this assay, from the lowest: compounds 2 and 3 (each within the scatter of the next); then compounds 4 and 1 (each within the scatter of the next).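

In this assay, the exchange of bromo for ethylamino on a saturated chain carbon bound to a carbonyl carbon gives a 1.1-fold lower number from compound 1 to compound 4 (0.03 log units; within the scatter). Among the compounds shown here, this is the first direct reading at this position: on the core of compound 1, losing bromo does not by itself move the number beyond the scatter. Nothing available explains this result.

On these data alone, how a dimethylamino group, a longer chain such as butylamino, or a carboxylic acid would read at this place on the same core remains open.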